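This account rests on a few compounds, and the source may have more. Where it says the series, first, only, none or still open, it means among the compounds named here.

Working notes on the series. In a functional assay on HEK293 cells for agonist activity at nuclear receptor subfamily 1 group D member 1 (Homo sapiens), read by a luciferase reporter, with a stated time of 24 h (a higher number here means that more compound is needed for the effect, a lower number that less compound is needed), compound 1 `CC(C)(C)OC(=O)CN(Cc1ccc(Cl)cc1)Cc1cccs1` is recorded as "not determined" (no result reported), and compound 3 `O=C(O)CN(Cc1ccc(Cl)cc1)Cc1ccc([N+](=O)[O-])s1` is recorded as "not determined" (no result reported), so neither has a single number; of the measured set only compound 2 `CC(C)(C)OC(=O)CN(Cc1ccc([N+](=O)[O-])cc1)Cc1ccc([N+](=O)[O-])s1` carries a value, giving 2500 nM in this assay. Among the measured compounds shown here, compound 3 therefore stands without a measured position, and no step to it from any other compound can be stated. Compound 4 `O=[N+]([O-])c1ccc(CN(Cc2ccc(Cl)cc2)CC2CCCCC2)s1` differs from compound 3 by the change (cyclohexyl in place of carboxy on a saturated chain carbon bound to an amine nitrogen), which removes a donor and acceptor and brings in a saturated ring. For the measured compounds named here, with no measured step available, the size or direction of the move in this assay cannot be drawn from the numbers here. Taking compound 2 as the only anchor, compound 4 is expected to give about 1500 nM, with a likely range from 400 nM to 6000 nM.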

Compound 4, half-maximal effective concentration: 7400 nM
For compound 4 the middle estimate is 4.9-fold (0.69 log units) below the measured one; measured number outside the range, above it.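

Among the compounds shown here, compound 3 has no single number in this assay, and no step from it to compound 4 can be read. The compounds shown leave open how cyclohexyl in place of carboxy moves the effective concentration. No evidence bears on this result.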